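This account rests on a few compounds, and the source may have more. Where it says the series, first, only, none or still open, it means among the compounds named here.

Compound 1 `C=CC(=O)N[C@@H]1CCN(S(=O)(=O)c2c(C(N)=O)[nH]c3ccc(Br)cc23)C1` carries a vinylcarbonyl group on an amine nitrogen whose other neighbour is a saturated ring carbon. Going by the values given here, in an ADME assay on MT4 cells (Homo sapiens) for cytotoxicity, read by MTT assay, with a stated time of 5 days (on this read-out higher numbers stand for lower toxicity in this test and lower numbers for higher toxicity in this test), compound 1 gives 178000 nM, the highest of the three numbers measured so far. Compound 2 `C=CC(=O)N1CC[C@H](NS(=O)(=O)c2c(C(N)=O)[nH]c3ccc(Br)cc23)C1` is a close relative, and in this assay compound 2 gives 155000 nM; this and the number for compound 1 lie within the scatter of each other. Compound 3 `C=CS(=O)(=O)N1CC[C@H](NS(=O)(=O)c2c(C(N)=O)[nH]c3ccc(Br)cc23)C1` is compound 2 with a vinylsulfonyl group in place of the vinylcarbonyl group on an amine nitrogen in a ring, and in this assay compound 3 gives 16000 nM. Among the compounds with values here, the one measured step, a 9.7-fold lower number from compound 2 to compound 3 (0.99 log units; beyond the scatter), is the only one that bears on the question here.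

Compound 4 `C=CS(=O)(=O)N[C@@H]1CCN(S(=O)(=O)c2c(C(N)=O)[nH]c3ccc(Br)cc23)C1` differs from compound 1 in one place: vinylsulfonyl in place of vinylcarbonyl on an amine nitrogen. This is the same exchange as in the measured step, now made on the amine nitrogen whose other neighbour is a saturated ring carbon. One step is thin ground, but it is the only one available, so a drop of about the same size is expected for compound 4, namely an 8.1-fold lower number from compound 1 to compound 4 (0.91 log units; beyond the scatter). Compound 4 is therefore estimated to give 22000 nM in this assay, with a likely range from 7000 nM to 70000 nM.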

Compound 4, half-maximal cytotoxic concentration: 2100 nM
Estimate against measurement, compound 4: 10-fold (1.02 log units) above, outside the stated range (below it).
By their numbers in this assay, from the lowest: compound 4; then compound 3; then compounds 2 and 1 (each within the scatter of the next).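

The exchange of vinylcarbonyl for vinylsulfonyl lowers the number in both pairs, but the size of the drop is not the same: on the amine nitrogen whose other neighbour is a saturated ring carbon, this assay shows an 85-fold lower number from compound 1 to compound 4 (1.93 log units; beyond the scatter), whereas on the amine nitrogen in a ring it shows a 9.7-fold lower number from compound 2 to compound 3 (0.99 log units; beyond the scatter). Since a lower number here stands for higher toxicity in this test, the same vinylsulfonyl group is linked to a much larger rise in toxicity at the new position, so the size of the change seen in one setting does not carry over unchanged to the other. Nothing given here accounts for this difference in size between the two pairs.

Going by these compounds alone, with only two pairs, it remains open whether the larger drop belongs to vinylsulfonyl in particular or would also appear with another group on the same nitrogen, such as a propanoyl or an ethylsulfonyl group. Going by these compounds, it is equally open whether the difference between the two positions would persist if the bromine on the shared core were replaced by chlorine.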